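Adding bromo to compound 3: what to expect

This account rests on a few compounds, and the source may have more. Where it says the series, first, only, none or still open, it means among the compounds named here.

Compound 1 `Cn1cc(C(=O)N/N=C\c2c[nH]c3ccccc23)c2cc(Br)ccc21`: 14300 nM
Compound 2 `COc1ccc2[nH]cc(/C=N\NC(=O)c3cn(C)c4ccc(Br)cc34)c2c1`: 22700 nM
Compound 3 `Cn1cc(/C=N\NC(=O)c2cn(C)c3ccccc23)c2ccccc21`: 18900 nM

In a functional assay on MDA-MB-231 cells (Homo sapiens) for cytotoxicity, read by MTT assay, with a stated time of 4 h (on this read-out higher numbers stand for weaker inhibition and lower numbers for stronger inhibition), compound 3 gives 18900 nM, a number within the usual scatter of repeated measurements from both compound 1 and compound 2, so these three cannot be ranked.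

Next comes compound 4 `Cn1cc(/C=N\NC(=O)c2cn(C)c3ccc(Br)cc23)c2ccccc21`, which has not yet been measured. It differs from compound 3 by a single change, bromo in place of hydrogen on an aromatic carbon.

Among the compounds with values here, no measured step makes exactly this swap. The closest guide is a 1.6-fold higher number from compound 1 to compound 2 (0.20 log units; within the scatter), which comes from methoxy in place of hydrogen on an aromatic carbon. That step stayed within the scatter, but it involves a different group, so it is only a loose guide. On this evidence, no shift beyond the scatter is expected in this assay, in either direction.

The expected change is a 1.1-fold lower number from compound 3 to compound 4 (0.05 log units; within the scatter), which is too small to tell apart from the scatter. For compound 4 the estimated value is 17000 nM, with an expected range of 8000 nM to 33000 nM.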

Compound 4, half-maximal inhibitory concentration: 5490 nM
Compound 4: the middle estimate sits 3.1-fold (0.49 log units) above what was measured; the measured number lies below the stated range.
By their numbers in this assay, from the lowest: compound 4; then compounds 1, 3 and 2 (each within the scatter of the next).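

In this assay, within the data shown here, bromo in place of hydrogen on an aromatic carbon gives a 3.4-fold lower number from compound 3 to compound 4 (0.54 log units; beyond the scatter) and so passes the scatter, which no earlier step did; this place on the ring, meta to a fused ring and para to a fused ring, can therefore move the number through a single added heavy atom. With the bromo kept, methyl in place of hydrogen on an aromatic nitrogen gives a 2.6-fold lower number from compound 1 to compound 4 (0.42 log units; beyond the scatter) in the same assay, so a second single change also moves the number beyond the scatter. No evidence here explains why either change has this effect.

The compounds shown leave open whether this shift belongs to bromo itself or would also come with chloro or an amine at the same place. They also leave open whether a longer chain, such as ethyl, on that aromatic nitrogen would lower the number further or raise it.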